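Cytotoxicity in Vero cells: a pyrrolidine replaces methylpiperazine

The source may hold more compounds than are shown below. What is called first, only, known or untested is meant among the compounds shown, and "the series" means these compounds.

Compound 1 `CN(C)CCCc1ccc(C(=O)/C=C/c2ccc(Cl)cc2)cc1`: 5.92 ug/mL
Compound 2 `CN1CCN(c2ccc(C(=O)C3CC3c3ccc(Cl)cc3)cc2)CC1`: 82.1 ug/mL

In an ADME assay on Vero cells (Chlorocebus sabaeus) for cytotoxicity, with a stated time of 72 h (on this read-out lower numbers stand for higher toxicity in this test and higher numbers for lower toxicity in this test), compound 2 gives the highest of the two numbers, with compound 1 the nearest at a markedly lower value. Compound 3 `O=C(c1ccc(N2CCCC2)cc1)C1CC1c1ccc(Cl)cc1` differs from compound 2 in one place: pyrrolidin-1-yl in place of 4-methylpiperazin-1-yl on an aromatic carbon. Among the measured compounds shown here, no measured pair shows this change, so its effect is unknown. With compound 2 giving 82.1 ug/mL in this assay, the step from compound 2 to compound 3 is expected to be small, a 1.6-fold lower number from compound 2 to compound 3 (0.22 log units; within the scatter), downward if anything. Compound 3 is estimated at 50 ug/mL, within 18 ug/mL to 130 ug/mL.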

Compound 3, half-maximal cytotoxic concentration: 431 ug/mL
The estimate for compound 3 lay 8.6-fold (0.94 log units) below the measured number, outside the stated range (above it).
By their numbers in this assay, from the lowest: compound 1; then compound 2; then compound 3.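

In this assay the change from 4-methylpiperazin-1-yl to pyrrolidin-1-yl on the aromatic carbon gives a 5.2-fold higher number from compound 2 to compound 3 (0.72 log units; beyond the scatter) and so shows that the number responds to the ring held at this position. Among the compounds shown here, compound 1 differs from compound 2 in more than one place, so this is the first single change that can be read here. Nothing available accounts for the step. Still open, from the compounds shown here alone, is whether a morpholine or piperidine ring at this place would track compound 2 or compound 3, and whether the same change would hold on the core of compound 1.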